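Side-chain swap on a flat series of three

The source may report more compounds than this note shows. Statements on the series, on what has been measured and on what is new or still open speak of the compounds shown alone.

Measured in a functional assay on MCF7 cells (Homo sapiens) for inhibition, read by MTT assay, with a stated time of 3 days; on this read-out lower numbers stand for stronger inhibition and higher numbers for weaker inhibition:
compound 1 `COc1cc(-c2nc3ccccc3s2)ccc1OCC(=O)NNC(O)CN(C)CC(=O)O` gives 1960 nM
compound 2 `COc1cc(-c2nc3ccccc3s2)ccc1OCC(=O)NNC(=O)CN(C(C)=O)[C@@H](CS)C(=O)O` gives 1750 nM
compound 3 `COc1cc(-c2nc3ccccc3s2)ccc1OCC(=O)NNC(=O)CNC(=N)NCCC[C@H](N[N+](=O)[O-])C(=O)O` gives 1960 nM

The three compounds share one core and differ in the chain attached to it. In this assay compound 2 (1750 nM) stands level with compound 1 (1960 nM) and with compound 3 (1960 nM), all within the usual scatter, so no order can be read among them.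

Compound 4 (`CCOC(=O)[C@H](NCC(=O)NNC(=O)COc1ccc(-c2nc3ccccc3s2)cc1OC)[C@@H](C)CC`) has not yet been measured. Compared with compound 2, it carries (1-(ethoxycarbonyl)-2-methylbutyl)amino in place of acetyl(1-carboxy-2-sulfanylethyl)amino on a saturated chain carbon bound to a carbonyl carbon.

For the measured compounds named here, no two measured compounds differ in one place only, so the data offer no direct guide to this change. Going by the values given here, no measured compound carries the ethoxycarbonyl group either. The only support is indirect: the chains of compound 1 (1960 nM) and compound 3 (1960 nM) differ from that of compound 2 (1750 nM), yet the values stay level. No step beyond the scatter is therefore expected in this assay, in either direction. The expected step is small (a 1.0-fold lower number from compound 2 to compound 4 (0.01 log units; within the scatter)). Compound 4 is estimated at 1700 nM (expected range 600 nM to 4500 nM).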

Compound 4, half-maximal inhibitory concentration: 2900 nM
Estimate against measurement, compound 4: 1.7-fold (0.23 log units) below; measured number inside the range.
By their numbers in this assay, from the lowest: compounds 2, 1, 3 and 4 (each within the scatter of the next).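

In this assay, replacing acetyl(1-carboxy-2-sulfanylethyl)amino with (1-(ethoxycarbonyl)-2-methylbutyl)amino on a saturated chain carbon bound to a carbonyl carbon gives a 1.7-fold higher number from compound 2 to compound 4 (0.22 log units; within the scatter), so no change can be claimed for this swap. Compound 4 is the first compound shown with an ethoxycarbonyl group where the others carry a free carboxylic acid, and its chain also has no sulfanyl group or acetyl on the nitrogen, so this position tolerates that combined exchange without a step beyond the scatter. Nothing available explains the size of this step or links it to any one part of the change.

The step from compound 2 to compound 4 changes these features together, so the compounds shown cannot separate the contribution of the ethoxycarbonyl group from that of the lost sulfanyl or acetyl group. As far as these compounds go, it remains open how the free carboxylic acid of the 2-methylbutyl chain or a plain primary amine at this position would compare, and whether any chain here can move the number beyond the scatter.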